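The compounds below may be only part of what the source reports. "The series", "measured", "known", "first", "only" and "open" are said of these compounds alone.

Going by the values given here, compound 2 `CCCCCCCCCCc1cc2cn(COCCO)c(=O)nc2o1` is the only member of this small set that gives a plain number. In a functional assay on HEL cells (Homo sapiens), read by microscopy (a higher number here means that more compound is tolerated, a lower number that less compound is tolerated), compound 2 gives 400000 nM. Compound 1 `CCCCCCc1cc2cn(COCCO)c(=O)nc2o1` is its close relative. In this assay compound 1 reaches only a limit of the assay, >= 400000 nM. The step of a number no higher from compound 1 to compound 2 (the limit leaves the size open) therefore has no readable size, and the limit of >= 400000 nM in this assay, at which 1 of the 2 values shown sits, is where one of the two values sits. Compound 3 `CCCCCc1cc2cn(COCCO)c(=O)nc2o1` has not yet been measured. It differs from compound 2 in one place: hydrogen in place of pentyl on a saturated chain carbon, five bonds along the chain from an aromatic carbon. Among the compounds with values here, the single measured step, from compound 1 to compound 2, bears on this change in the opposite direction and shows nothing that can be read beyond the scatter, so no step of readable size is expected here either. Compound 3 is therefore expected to give 400000 nM in this assay, between 200000 nM and 800000 nM. The step of no change at the digits printed from compound 2 to compound 3 (within the scatter) is expected to stay within the scatter.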

Compound 3, minimum cytotoxic concentration: > 400000 nM
Compound 3: only a limit was reported; the forecaster's own chance of this, stated with the estimate: 70%; the middle value lies on the limit itself.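

In this assay compound 3 gives only a limit of the assay, > 400000 nM. This adds a second, shorter chain length, with hydrogen in place of pentyl at this position, and the change brings a number no lower from compound 2 to compound 3 (the limit leaves the size open). The sizes of the steps to compound 3, from compound 2 and from compound 1 alike, cannot be read because the values stop at limits: the limit of > 400000 nM in this assay, at which 1 of the 3 values shown sits.

Going by these compounds, only compound 2 gives a plain number, so how steeply the tolerated concentration in this assay follows chain length remains open. Also open, on these data alone, is whether a longer chain than that of compound 2, or an amine or a carboxylic acid at the end of the chain, would give a lower plain number in this assay.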